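Chain length at the sulfur in the galloyl series

The source may hold more compounds than are shown below. What is called first, only, known or untested is meant among the compounds shown, and "the series" means these compounds.

Of the compounds shown here, two carry numbers so far in an assay on RAW264.7 cells for antagonist activity at Toll-like receptor 2 (Mus musculus), read by Griess assay, with a stated time of 24 h; a higher number here means a weaker inhibitor, a lower number a stronger inhibitor. Compound 1 `C=CCCSC[C@H](N)C(=O)OC` gives 45500 nM in this assay. Compound 2 `C=CCSC[C@H](NC(=O)c1cc(O)c(O)c(O)c1)C(=O)OC`, which joins the shorter unsaturated chain on the sulfur to the trihydroxybenzoyl amide, gives 52100 nM in this assay; that is the higher of the two numbers, but the gap to compound 1 lies within the scatter, so the two cannot be ordered.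

Compound 3 `C=CCCSC[C@H](NC(=O)c1cc(O)c(O)c(O)c1)C(=O)OC` has not been measured. It differs from compound 2 in one place: allyl in place of vinyl on a saturated chain carbon bound to a sulfur. Within the data shown here, no pair of measured compounds isolates this chain extension, so nothing measured speaks to it directly; the only related observation is that compound 1, which already carries the longer chain without the amide, sits within the scatter of compound 2.

With that, no step beyond the scatter is expected for a 1.0-fold lower number from compound 2 to compound 3 (0.02 log units; within the scatter) in this assay, in either direction. Compound 3 is accordingly expected to give about 50000 nM in this assay, with a likely range from 25000 nM to 100000 nM.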

Compound 3, half-maximal inhibitory concentration: 57800 nM
For compound 3 the middle estimate is 1.2-fold (0.06 log units) below the measured one; the range from low to high includes it.
By their numbers in this assay, from the lowest: compounds 1, 2 and 3 (each within the scatter of the next).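

In this assay, the change from allylsulfanyl to (but-3-en-1-yl)sulfanyl, with the trihydroxybenzoyl amide and the methyl ester held constant, gives a 1.1-fold higher number from compound 2 to compound 3 (0.05 log units; within the scatter). Among these compounds, this is the first pair that isolates the chain on the sulfur, and it shows that allyl in place of vinyl on a saturated chain carbon bound to a sulfur produces no readable difference in this read-out. No measurement on these compounds bears on the reason for this result.

Going by these compounds, whether a longer chain on the sulfur, a saturated butyl chain without the double bond, or a carboxylic acid in place of the methyl ester would give a step beyond the scatter remains open. On these data alone, it is also open whether the same chain change would read the same way on the free amine, or on an amide with a benzoyl group carrying no hydroxyl groups.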